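Swapping One Aromatic Ring on a Weak Compound

The compounds below may be only part of what the source reports. "The series", "measured", "known", "first", "only" and "open" are said of these compounds alone.

In a functional assay on Z-138 cells (Homo sapiens) for antiproliferative activity, with a stated time of 72 h (on this read-out higher numbers stand for weaker inhibition and lower numbers for stronger inhibition), compound 1 `Nc1ncnn2c([C@@H]3O[C@H](CO)[C@@H](O)[C@H]3O)cc(C#CC3CC3)c12` gives 20 nM. Compound 2 `COc1ccc(-c2cc([C@@H]3O[C@H](CO)[C@@H](O)[C@H]3O)n3ncnc(N)c23)cc1` gives 62600 nM, the higher of the two numbers and therefore the weaker inhibition. Among the compounds with values here, the only measured step is a 3100-fold higher number from compound 1 to compound 2 (3.50 log units; beyond the scatter), a large change beyond the scatter, made by putting 4-methoxyphenyl in place of 2-cyclopropylethynyl on an aromatic carbon.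

Compound 3 `Cc1ccccc1-c1cc([C@@H]2O[C@H](CO)[C@@H](O)[C@H]2O)n2ncnc(N)c12` has not yet been measured. It keeps the shared core and carries 2-methylphenyl in place of 4-methoxyphenyl on that same aromatic carbon (2-methylphenyl in place of 4-methoxyphenyl on an aromatic carbon). The leaving and entering groups each hold one six-membered aromatic ring of carbon only, whereas the measured step replaced 2-cyclopropylethynyl. Within the data shown here, that step therefore offers only an indirect guide, and no measured pair compares two such rings. A far smaller change is expected here, with little basis for its direction. The expected result is a 1.6-fold lower number from compound 2 to compound 3 (0.19 log units; within the scatter), an estimate that leans only slightly towards stronger inhibition. In this assay, compound 3 is estimated at 40000 nM, with an expected range from 8000 nM to 120000 nM.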

Compound 3, half-maximal inhibitory concentration: 66000 nM
Compound 3: middle estimate off by 1.7-fold (0.22 log units), on the low side, and the stated range covers the measured number.
By their numbers in this assay, from the lowest: compound 1; then compounds 2 and 3 (each within the scatter of the next).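

Putting 2-methylphenyl in place of 4-methoxyphenyl on this aromatic carbon gives a 1.1-fold higher number from compound 2 to compound 3 (0.02 log units; within the scatter) in this assay, so the two rings cannot be told apart here, even though they carry different groups and only the leaving one holds an oxygen. The earlier compounds shown here offered a single six-membered aromatic ring at this place, and this result adds a second one with a different group on it. Compared with 2-cyclopropylethynyl, this second ring also gives a large step, a 3300-fold higher number from compound 1 to compound 3 (3.52 log units; beyond the scatter), so both carbon-only aromatic rings shown here stand far from compound 1, and neither of them goes against that pattern.

The compounds shown leave open whether an amine, a plain ethynyl group without the cyclopropyl ring, or a pyridine ring holding nitrogen on this carbon would bring the number back towards that of compound 1. No measurement given here bears on why 2-cyclopropylethynyl and these two aromatic rings end up so far apart.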